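Swapping the aryl group on a piperazine nitrogen

This account rests on a few compounds, and the source may have more. Where it says the series, first, only, none or still open, it means among the compounds named here.

Of the compounds shown here, two sharing one core have been tested in a functional assay on the whole organism (strain Wister albino) for inhibition, with Rattus norvegicus as the target, read by paw edema, with stated times of 30 min and 3 h, at a dose of 10 mg/kg by the oral route; a lower number here means less inhibition, a higher number more inhibition at the dose given (going by the name of the read-out). Compound 1 `CSc1ccc(Cc2nn(CN3CCN(c4ccc([N+](=O)[O-])cc4)CC3)c(=S)o2)cc1` gives 56.6%. Going by the values given here, compound 2 `CSc1ccc(Cc2nn(CN3CCN(c4ccc(F)cc4)CC3)c(=S)o2)cc1` gives 68.7%, which is the higher of the two numbers; the only measured step, a number 12.1 percentage points higher from compound 1 to compound 2 (beyond the scatter), lies beyond the scatter and brings fluoro in place of nitro on an aromatic carbon of the group attached to the ring nitrogen.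

Compound 3 `CCOc1ccccc1N1CCN(Cn2nc(Cc3ccc(SC)cc3)oc2=S)CC1` is not yet measured. It differs from compound 2 in one place: 2-ethoxyphenyl in place of 4-fluorophenyl on an amine nitrogen in a ring. Among the compounds with values here, this is a change at the same position as the measured step, but it replaces the whole group rather than a single substituent, and no measured pair shows 2-ethoxyphenyl at all. Within the data shown here, the one known step therefore offers only weak guidance, and it was modest in size.

For this reason a step of about a number 6.7 percentage points lower from compound 2 to compound 3 (within the scatter) is expected, that is, nothing clearly beyond the scatter in either direction. Compound 3 is estimated to give 62% in this assay, with a range from 45% to 78%.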

Compound 3, a percentage reported as inhibition, in the whole organism at one dose (the size of the read-out at that dose, not a potency): 42.5%
Estimate against measurement, compound 3: 19.5 percentage points above, outside the stated range (below it).
By their numbers in this assay, from the lowest: compound 3; then compound 1; then compound 2.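

In this assay, putting 2-ethoxyphenyl on the amine nitrogen in the ring gives a number 26.2 percentage points lower from compound 2 to compound 3 (beyond the scatter) and a number 14.1 percentage points lower from compound 1 to compound 3 (beyond the scatter), so compound 3 sits below both the 4-fluorophenyl and the 4-nitrophenyl compounds. The earlier pair showed only that the read-out responds when one substituent on the aryl group is exchanged, with the higher number going to 4-fluorophenyl; this result shows that an exchange of the whole aryl group at this position can lower the read-out past both of those levels. No measurement bearing on why these numbers differ is available here.

Compound 3 changes two things at once, the kind of substituent and where it stands on the aromatic ring, and the compounds shown cannot tell these two apart; 4-ethoxyphenyl or 2-fluorophenyl on the same nitrogen would separate them. On these data alone, it also remains open how far the read-out depends on having an aryl group there at all, which a plain phenyl, a benzyl or a simple methyl group on that nitrogen would begin to answer.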